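The compounds below may be only part of what the source reports. "The series", "measured", "known", "first", "only" and "open" are said of these compounds alone.

Measured so far:
Compound 1, `FC(F)(F)c1ccc(CSc2nc(Nc3ccccc3Cl)c3ccccc3n2)cc1`: in a functional assay on MDA-MB-231 cells (Homo sapiens) for cytotoxicity, read by MTT assay, with a stated time of 72 h (on this read-out higher numbers stand for weaker inhibition and lower numbers for stronger inhibition), compound 1 gives > 50000 nM, a limit of the assay.
Compound 2, `CCOc1ccccc1Nc1nc(SCc2ccc(C(F)(F)F)cc2)nc2ccccc12`: in this assay compound 2 gives > 50000 nM, also a limit.
Compound 3, `Cc1ccccc1Nc1nc(SCc2ccc(C(F)(F)F)cc2)nc2ccccc12`: in this assay compound 3 gives 27100 nM.

Among the measured compounds shown here, compound 3 thus holds the only number among the three; the other two values sit at the limit of > 50000 nM in this assay, at which 2 of the 3 values shown sit. The steps of an at least 1.8-fold lower number from compound 1 to compound 3 (0.26 log units; that floor lies within the scatter) and an at least 1.8-fold lower number from compound 2 to compound 3 (0.26 log units; that floor lies within the scatter) are floors only, and a step that the two limits leave unreadable from compound 1 to compound 2 cannot be read. Compound 4, `FC(F)(F)c1ccc(CSc2nc(Nc3cccc(C(F)(F)F)c3)c3ccccc3n2)cc1`, differs from compound 3 by 3-(trifluoromethyl)phenyl in place of 2-methylphenyl on a nitrogen on an aromatic ring. For the measured compounds named here, no measured step introduces a trifluoromethyl-bearing ring on this nitrogen, so the measured steps give no direction for it. Compound 4 is therefore expected near the limit, an expected step of a 1.7-fold higher number from compound 3 to compound 4 (0.22 log units; within the scatter), with the estimate 45000 nM spanning 15000 nM to 150000 nM.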

Compound 4, half-maximal inhibitory concentration: 11100 nM
The estimate for compound 4 lay 4.1-fold (0.61 log units) above the measured number; measured number below the stated range.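

Among the compounds shown here, replacing 2-methylphenyl with 3-(trifluoromethyl)phenyl on the nitrogen gives, in this assay, a 2.4-fold lower number from compound 3 to compound 4 (0.39 log units; beyond the scatter), the only step at this position read between two numbers rather than against a limit. Against the other two groups on this nitrogen, the change gives an at least 4.5-fold lower number from compound 2 to compound 4 (0.65 log units; beyond the scatter) and an at least 4.5-fold lower number from compound 1 to compound 4 (0.65 log units; beyond the scatter), so compound 4 now holds the lowest number of the four. Those two steps are floors only: the limit of > 50000 nM in this assay, at which 2 of the 4 values shown sit.

Because the group and its place on the ring change together here, the compounds shown cannot separate the two. Going by these compounds, how an amine or a carboxylic acid on this ring would read also stays open.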